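The source may report more compounds than this note shows. Statements on the series, on what has been measured and on what is new or still open speak of the compounds shown alone.

Three triazenes carry the shared core of compound 1 `Cc1ccc(/N=N/N(C)C)cc1`. In a functional assay on L1210 cells (Mus musculus) for antiproliferative activity (a lower number here means a less potent compound, a higher number a more potent compound, by a factor of ten per unit of this negative logarithm), compound 1 gives 3.76. Compound 2 `CN(C)/N=N/c1ccc(C(N)=O)cc1` differs from it only in the group on the aromatic carbon, and in this assay compound 2 gives 3.51; the step of a number 0.25 log units lower from compound 1 to compound 2 (within the scatter) stays within the scatter. Compound 3 `CCN(C)/N=N/c1ccc(NC(N)=O)cc1` gives 3.87 in this assay, which is the highest of the three numbers, although it sits within the scatter of compound 1 and beyond the scatter only of compound 2.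

Compound 4 `CN(C)/N=N/c1ccc(NC(N)=O)cc1` is the next member and awaits measurement in this assay. It differs from compound 3 in one place: hydrogen in place of methyl on a saturated chain carbon bound to an amine nitrogen. Among the compounds with values here, none of the measured steps touches this part of the molecule; the only measured step, between compound 1 and compound 2, concerns the aromatic substituent, so it does not bear on the change from an ethyl(methyl)amino to a dimethylamino group. Within the data shown here, with no step to rest on, one expects the loss of a single carbon from the saturated chain to move the number little, if at all beyond the scatter. The estimated step is a number 0.07 log units lower from compound 3 to compound 4 (within the scatter). Compound 4 is therefore expected to give about 3.8 in this assay, within a range from 3.4 to 4.2.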

Compound 4, logarithm of the reciprocal of the active concentration, log(1/C): 3.97
For compound 4 the middle estimate is 0.17 log units below the measured one; low and high end bracket the measured number.
By their numbers in this assay, from the lowest: compounds 2, 1, 3 and 4 (each within the scatter of the next, the first and the last beyond it).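

In this assay, within the data shown here, the change from ethyl(methyl)amino to dimethylamino, hydrogen in place of methyl on a saturated chain carbon bound to an amine nitrogen, gives a number 0.10 log units higher from compound 3 to compound 4 (within the scatter), which is the first reading at this position and shows that losing this one carbon leaves the result within the usual spread of repeats. With the dimethylamino group held constant, compound 4 also allows a new comparison on the aromatic carbon, where ureido in place of carbamoyl gives a number 0.46 log units higher from compound 2 to compound 4 (beyond the scatter), a modest step that clears the scatter. Ureido in place of methyl on an aromatic carbon gives a number 0.21 log units higher from compound 1 to compound 4 (within the scatter), so among these three groups only the ureido and carbamoyl pair is separated by a step beyond the scatter.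

As far as these compounds go, whether a longer chain such as butyl on the amine nitrogen, or a carboxylic acid on the aromatic carbon, would keep the number in this range remains open. No evidence accompanies these numbers that could account for any of these steps.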